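This account rests on a few compounds, and the source may have more. Where it says the series, first, only, none or still open, it means among the compounds named here.

Measured compounds:
compound 1, `Cc1ccc(N2CCN(CCCn3nc(-c4ccccc4)c(C#N)c3C)CC2)cc1`: 30%
compound 2, `Cc1c(C#N)c(-c2ccccc2)nn1CCCN1CCN(c2ccc([N+](=O)[O-])cc2)CC1`: 49%
compound 3, `CC(=O)c1cccn1CCCN1CCN(c2ccc(C)cc2)CC1`: 9%

All three were tested in a functional assay on the whole organism (Abdomen, strain Swiss) for inhibition, with Mus musculus as the target, with stated times of 30 min, 10 min and 5 min, at a dose of 40 mg/kg by the oral route; a higher number here means a stronger effect of the compound at the dose given, a lower number a weaker effect. Compound 1 and compound 2 share a core and differ in one place, (nitro in place of methyl on an aromatic carbon). That change produced a number 19 percentage points higher from compound 1 to compound 2 (beyond the scatter). Compound 3 is built on another core; the difference between the two cores is not broken down here. Compound 4, `CC(=O)c1cccn1CCCN1CCN(c2ccc([N+](=O)[O-])cc2)CC1`, has not yet been measured; it is related to compound 3 by nitro in place of methyl on an aromatic carbon, the same change that turns compound 1 into compound 2. If this change acts alike on the core of compound 3, compound 4 is expected to show a step of a number 19 percentage points higher from compound 3 to compound 4 (beyond the scatter), an expectation that rests on the single earlier step of a number 19 percentage points higher from compound 1 to compound 2 (beyond the scatter). The estimate for compound 4 in this assay is therefore 28%, expected to fall between 10% and 48%.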

Compound 4, a percentage reported as inhibition, in the whole organism at one dose (the size of the read-out at that dose, not a potency): 0%
Compound 4: the middle estimate sits 28 percentage points above what was measured; the measured number lies below the stated range.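

In this assay, nitro in place of methyl on an aromatic carbon did not behave the same way on the two cores: the same change on two cores in this assay, a number 19 percentage points higher (beyond the scatter) from compound 1 to compound 2 and a number 9 percentage points lower (within the scatter) from compound 3 to compound 4, 28 percentage points apart, beyond the scatter of two such steps. On the core of compound 3, the change gives a number 9 percentage points lower from compound 3 to compound 4 (within the scatter), so the rise seen on the other core did not carry over, and this step cannot be told apart from no effect. Among these compounds, with only two pairs, this shows that a step measured on one core cannot safely be transferred to the other, but it does not show which part of the cores makes the difference.

On these data alone, it remains open whether an amine or a carboxylic acid in that same place would give matching steps on both cores. As far as these compounds go, the effect of a longer chain also remains open.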